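The source may hold more compounds than are shown below. What is called first, only, known or untested is meant among the compounds shown, and "the series" means these compounds.

Measured in a functional assay on DU-145 cells (Homo sapiens) for cytotoxicity, read by trypan blue exclusion, with a stated time of 96 h; on this read-out higher numbers stand for weaker inhibition and lower numbers for stronger inhibition:
- compound 1 (`COc1ccc(NS(=O)(=O)/C=C/c2ccc(OC)cc2OC)cc1`): 15000 nM
- compound 2 (`COc1ccc(NS(=O)(=O)/C=C/c2c(OC)cccc2OC)cc1`): 375 nM
- compound 3 (`COc1ccc(NS(=O)(=O)/C=C/c2c(OC)cc(OC)cc2OC)cc1`): 200 nM

Two measured steps end at the same compound. One is large and beyond the scatter (a 75-fold lower number from compound 1 to compound 3 (1.88 log units; beyond the scatter)). The other stays within the scatter (a 1.9-fold lower number from compound 2 to compound 3 (0.27 log units; within the scatter)). Compound 3 therefore sits level with compound 2 and far from compound 1 on these numbers.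

The next change leads to compound 4 (`COc1ccc(NS(=O)(=O)/C=C/c2c(OC)cc(O)cc2OC)cc1`), methoxy to hydroxy (hydrogen in place of methyl on an oxygen on an aromatic ring), that is, hydrogen in place of methyl on an oxygen on an aromatic ring. Among the compounds with values here, the methoxy concerned is the one compound 2 lacks, so the small step (a 1.9-fold lower number from compound 2 to compound 3 (0.27 log units; within the scatter)) bears most directly on it: gaining that whole group moved the number by no more than the scatter. The large step (a 75-fold lower number from compound 1 to compound 3 (1.88 log units; beyond the scatter)) concerns a different methoxy, which compound 4 keeps, and says little here. Within the data shown here, no hydroxy compound has been measured, so the direction rests on weak ground. In this assay a small rise in the number is expected, not clearly beyond the scatter (a 1.9-fold higher number from compound 3 to compound 4 (0.28 log units; within the scatter)). Compound 4 is estimated at 380 nM (expected range 130 nM to 1500 nM).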

Compound 4, half-maximal inhibitory concentration: 10000 nM
Compound 4: middle estimate off by 26-fold (1.42 log units), on the low side, and the stated range ends below it.
By their numbers in this assay, from the lowest: compounds 3 and 2 (each within the scatter of the next); then compounds 4 and 1 (each within the scatter of the next).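

In this assay this carbon turns out not to be indifferent to what it carries: hydrogen and methoxy stand level here (a 1.9-fold lower number from compound 2 to compound 3 (0.27 log units; within the scatter)), whereas hydroxy stands well apart from both (a 50-fold higher number from compound 3 to compound 4 (1.70 log units; beyond the scatter); a 27-fold higher number from compound 2 to compound 4 (1.43 log units; beyond the scatter)). The small step from hydrogen to methoxy therefore did not predict the outcome for every group at this place, and the loss of a single methyl from the oxygen on the aromatic ring, with the rest of compound 3 unchanged, is enough for a large step. Nothing at hand explains this step, so the result stands as an observation only.

Still open, from the compounds shown here alone, is whether the large step belongs to hydroxy in particular or would also appear with other groups on this carbon, such as an amine, a carboxylic acid, a fluorine or a longer alkoxy chain like ethoxy. Also open, going by these compounds, is whether replacing either of the other two methoxy groups on this ring with hydroxy would give a step of similar size, and whether the same gap appears on cells other than those of this assay.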